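The source may hold more compounds than are shown below. What is called first, only, known or untested is meant among the compounds shown, and "the series" means these compounds.

Of the compounds shown here, two of this study have been measured in an assay on isolated protein for inhibition of Polyunsaturated fatty acid 5-lipoxygenase (Homo sapiens), read by fluorescence, with a stated time of 10 min; on this read-out higher numbers stand for weaker inhibition and lower numbers for stronger inhibition. Compound 1, with the structure `O=C(Oc1cccc2ccccc12)c1cccc([N+](=O)[O-])c1`, gives 7100 nM there. Compound 2, with the structure `O=C(Nc1cccc(Cl)c1)c1cc([N+](=O)[O-])cc([N+](=O)[O-])c1`, gives 33 nM in this assay. For the measured compounds named here, on these two numbers compound 2 stands lowest; the only other number, that of compound 1, lies far above it, a gap beyond the scatter, though the two structures differ in several places at once and no single step can be read from them.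

Compound 3, with the structure `O=C(Nc1cccc(Br)c1)c1cc([N+](=O)[O-])cc([N+](=O)[O-])c1`, has not yet been measured. It differs from compound 2 in one place only: bromo in place of chloro on an aromatic carbon of a six-membered aromatic ring of carbon only, meta to a large group. Going by the values given here, no step between measured compounds speaks to this change, so the expectation rests on the closeness of the two structures alone. Compound 3 is expected to stay close to compound 2, with a step of a 1.1-fold lower number from compound 2 to compound 3 (0.04 log units; within the scatter) that should fall within the scatter in either direction. Compound 3 is therefore estimated at 30 nM, with a range from 12 nM to 80 nM.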

Compound 3, half-maximal inhibitory concentration: > 50000 nM
Compound 3 was reported as a limit; the forecaster's own chance of this, stated with the estimate: 2%; at least 1600-fold (3.22 log units) between middle value and limit.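

The earlier compounds shown here offered no step to judge by, and this pair shows that the read-out can answer sharply at this place, on an aromatic carbon meta to a large group, to the exchange of a single heavy atom: bromo in place of chloro gives an at least 1500-fold higher number from compound 2 to compound 3 (3.18 log units; beyond the scatter). On the counts computed for the two groups, the change alters neither hydrogen-bond donors nor acceptors, and neither group carries a net charge, so the 3-chlorophenyl to 3-bromophenyl change is small on paper yet large in this assay. Compound 3 is reported as a limit and not as a number, so the step is a bound whose true size stays unknown: the limit of > 50000 nM in this assay, at which 1 of the 3 values shown sits.

The compounds shown leave open whether chloro is unusual at this place or bromo alone stands apart, as fluoro, methyl, methoxy or an amine on the same aromatic carbon would be needed to tell the two readings apart. For the compounds shown here, they also leave open whether the same exchange would weigh as heavily on another core, and the single pair offers no cause for the step.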